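The source may hold more compounds than are shown below. What is called first, only, known or untested is meant among the compounds shown, and "the series" means these compounds.

Measured in an assay for inhibition of MAP kinase-interacting serine/threonine-protein kinase 2 (Homo sapiens), read by luminescence and ADP-Glo, with a stated time of 2 h; a lower number here means a stronger inhibitor, a higher number a weaker inhibitor:
compound 1 `Cn1ncc2ccc(-c3ccc(=O)n(Cc4ccccc4)c3)cc21`: > 2000 nM, a limit of the assay.
compound 2 `O=c1ccc(-c2ccc3cc[nH]c3c2)cn1Cc1ccccc1`: > 2000 nM, likewise a limit.

Compound 1 therefore stands at the limit of > 2000 nM in this assay, at which 2 of the 2 values shown sit, with no numeric value of its own in this assay. Compound 3 `O=c1ccc(-c2ccc3cn[nH]c3c2)cn1Cc1ccccc1` differs from compound 1 by hydrogen in place of methyl on an aromatic nitrogen. Among the compounds with values here, no measured step of this kind exists. Because both measured values sit at the limit of > 2000 nM in this assay, at which 2 of the 2 values shown sit, no movement beyond the scatter is expected in this assay. Compound 3 is estimated at 4000 nM, range 1500 nM to 20000 nM. The step is expected to be a step that the limit leaves unreadable from compound 1 to compound 3.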

Compound 3, half-maximal inhibitory concentration: 75 nM
For compound 3 the middle estimate is 53-fold (1.73 log units) above the measured one; the measured number lies below the stated range.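

On the aromatic nitrogen of the five-membered ring, the change from methyl to hydrogen gives an at least 26-fold lower number from compound 1 to compound 3 (1.42 log units; beyond the scatter) in this assay. Within the data shown here, this position therefore strongly affects the read-out, and compound 3 gives the only numeric value shown, 75 nM. The step remains a bound, because its starting point is a limit: the limit of > 2000 nM in this assay, at which 2 of the 3 values shown sit.

From the compounds shown here alone, it remains open how far methyl truly lies from hydrogen at this position. Also open, going by these compounds, is whether an ethyl group, a longer chain or an amine-bearing chain on this nitrogen would read closer to compound 3 or to compound 1.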